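Swapping a bicyclic group for propylcarbonyl: cytotoxicity outlook

A few compounds are considered here, and "the series" means these few. Any claim that something is new, unique, unknown or untested is made for them only; others in the source may bear on it.

Compound 1 `c1ccc(-c2ccc(Cn3cncc3CNc3ccc(-c4onc5ccccc45)c(-c4ccccc4)c3)cc2)cc1` was tested in a toxicity assay on NIH3T3 cells (Mus musculus) for cytotoxicity, read by resazurin assay; a lower number here means that less compound is needed, a higher number that more compound is needed for the effect. In this assay compound 1 gives > 10000 nM, which is a limit of the assay rather than a number, so it stands at the limit of > 10000 nM in this assay, at which 1 of the 2 values shown sits, and not at a measured point. For the measured compounds named here, a second compound, compound 2 `COC(=O)c1ccc(NCc2cncn2Cc2ccccc2C#N)cc1-c1ccccc1`, gives 25000 nM in this assay, a value that the two compounds share in being weak on these cells; no step between them is computed, so their two values are only set side by side.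

Compound 3 `CCCC(=O)c1ccc(NCc2cncn2Cc2ccc(-c3ccccc3)cc2)cc1-c1ccccc1` has not been measured in this assay. It differs from compound 1 by a group of 5 heavy atoms (4 carbon, 1 oxygen; no ring) in place of a group of 9 heavy atoms (7 carbon, 1 nitrogen, 1 oxygen; one five-membered aromatic ring with 2 hetero atoms, one six-membered aromatic ring of carbon only), on an aromatic carbon. Going by the values given here, no measured step covers this change. Since both compounds already sit at the weak end of the scale, and compound 1 gives only a limit, the step from compound 1 to compound 3 is expected to be none beyond the scatter, with a step that the limit leaves unreadable from compound 1 to compound 3 as the estimated size. For compound 3 a value of 20000 nM is expected, within a range from 8000 nM to 60000 nM, and there is a fair chance the assay again reports only a limit.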

Compound 3, half-maximal effective concentration: > 10000 nM
Compound 3: no number, only a limit; the forecaster's own chance of this, stated with the estimate: 50%; the middle value lies beyond the limit too.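

No step can be read between compound 1 and compound 3, because both results are limits of the assay and not numbers: the limit of > 10000 nM in this assay, at which 2 of the 3 values shown sit.

The compounds shown leave open whether propylcarbonyl in place of the bicyclic group changes the result in this assay at all, and what concentration either compound would need for the effect.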